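The source may hold more compounds than are shown below. What is called first, only, known or untested is meant among the compounds shown, and "the series" means these compounds.

Two biguanide-type compounds have been tested so far. Compound 1 `N=C(NC(=N)NC1CCCC1)Nc1ccc(C(F)(F)F)cc1` carries a cyclopentylamino group and a trifluoromethyl-bearing ring. In a functional assay on A549 cells (Homo sapiens) for antiproliferative activity, read by MTT assay, with a stated time of 72 h (on this read-out lower numbers stand for stronger inhibition and higher numbers for weaker inhibition), compound 1 gives 1800 nM. Compound 2 `CCN(CC)C(=N)NC(=N)Nc1ccc(F)c(F)c1` instead carries a diethylamino group and a ring with two fluorine atoms, and in this assay compound 2 gives 7800 nM. Of these two numbers, compound 1 has the lower one, and the gap to compound 2 is wider than the usual run-to-run scatter.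

Compound 3 `CCN(CC)C(=N)NC(=N)Nc1ccc(C(F)(F)F)cc1` keeps the ring of compound 1 but changes the other end: diethylamino in place of cyclopentylamino on a carbon with a double bond to nitrogen. Among the compounds with values here, no measured pair shows this change on its own, so its effect is not known. Since compound 2, which carries the diethylamino group, has the weaker value, a modest loss is expected, with the step from compound 1 to compound 3 estimated at a 2.2-fold higher number from compound 1 to compound 3 (0.35 log units; beyond the scatter). Compound 3 is therefore expected to give about 4000 nM in this assay, somewhere between 1500 nM and 12000 nM.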

Compound 3, half-maximal inhibitory concentration: 3700 nM
Beside the measured number, compound 3's estimate is 1.1-fold (0.03 log units) above it; measured number inside the range.
By their numbers in this assay, from the lowest: compound 1; then compound 3; then compound 2.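

With the trifluoromethyl-bearing ring held fixed, the effect of this one end can now be read by itself. The earlier pair did not allow this: those compounds differed at both ends. In this assay putting diethylamino in place of cyclopentylamino on a carbon with a double bond to nitrogen gives a modest loss that lies beyond the scatter (a 2.1-fold higher number from compound 1 to compound 3 (0.31 log units; beyond the scatter)). Cyclopentylamino has a ring and a hydrogen-bond donor that diethylamino lacks, but no available measurement explains the change.

As far as these compounds go, it remains open whether the ring or the hydrogen-bond donor matters more, and how a cyclohexylamino group or a morpholine ring would fare at this place. From the compounds shown here alone, it is also open whether the same swap gives a similar step on the ring with two fluorine atoms.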